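This account rests on a few compounds, and the source may have more. Where it says the series, first, only, none or still open, it means among the compounds named here.

Measured so far in an ADME assay for permeability, using PAMPA, with a stated time of 4 h; a lower number here means that the compound crosses the layer more slowly, a higher number that the compound crosses the layer faster:
compound 1 `CCOC(=O)c1ccc(N2CCN(C)CC2)c(NC(=O)c2ccc(F)c(C)c2Cl)c1` gives 44.9 10^-6 cm/s
compound 2 `CC(C)OC(=O)c1ccc(N2CCN(C)CC2)c(NC(=O)c2ccc(F)c([N+](=O)[O-])c2)c1` gives 61.4 10^-6 cm/s
compound 3 `COC(=O)c1ccc(N2CCN(C)CC2)c(NC(=O)c2cc(N)c(F)c(C)c2Cl)c1` gives 52.9 10^-6 cm/s

Compound 3 stands second highest of the three numbers. Its nearest neighbour is compound 2 and its furthest is compound 1, and both gaps lie within the scatter, so the three measured compounds are not separated from one another in this assay.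

The next compound is compound 4 `Cc1c(F)c(N)cc(C(=O)Nc2cc(C(=O)Oc3ccccc3)ccc2N2CCN(C)CC2)c1Cl`. Against compound 3 the change is phenyl in place of methyl on an oxygen next to a carbonyl group. Going by the values given here, no step between measured compounds is available, so the weight of this change cannot be read from the series itself. A step within the scatter, or at most a small one upward, is expected from compound 3 to compound 4 a 1.0-fold higher number from compound 3 to compound 4 (0.02 log units; within the scatter). Compound 4 is estimated at 55 10^-6 cm/s, with a range of 30 10^-6 cm/s to 95 10^-6 cm/s.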

Compound 4, apparent permeability: 38 10^-6 cm/s
Compound 4: the middle estimate sits 1.4-fold (0.16 log units) above what was measured; the range from low to high includes it.
By their numbers in this assay, from the lowest: compounds 4, 1, 3 and 2 (each within the scatter of the next).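

In this assay, going by these compounds alone, the first step between compounds differing in one place is a 1.4-fold lower number from compound 3 to compound 4 (0.14 log units; within the scatter), for phenyl in place of methyl on an oxygen next to a carbonyl group. This position therefore carries six heavy atoms and an aromatic ring, where methyl has one heavy atom, with no step beyond the scatter. No available measurement bears on the origin of this step. Still open, from the compounds shown here alone, is how a carboxylic acid, or a longer chain carrying an amine, would read at this place. A single step also leaves open whether this change reads the same on other compounds.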